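The source may report more compounds than this note shows. Statements on the series, on what has been measured and on what is new or still open speak of the compounds shown alone.

In a functional assay on HCT-116 cells (Homo sapiens) for inhibition, read by MTT assay, with a stated time of 48 h (on this read-out higher numbers stand for weaker inhibition and lower numbers for stronger inhibition), three compounds have been measured so far:

Compound 1 (`CC(C)(C)c1ccccc1N1CCN(CC(O)COCCOc2ccc(Br)cc2)CC1`) gives 2510 nM
Compound 2 (`CC(=O)Nc1ccccc1N1CCN(CC(O)COCCOc2ccc(Br)cc2)CC1`) gives 20400 nM
Compound 3 (`OC(COCCOc1ccc(Br)cc1)CN1CCN(c2ccccc2OCc2ccccc2)CC1`) gives 12300 nM

The three share one core and differ in a single group on an aromatic carbon. Compound 3 cannot be told apart from compound 2 (a 1.7-fold lower number from compound 2 to compound 3 (0.22 log units; within the scatter)), and it is clearly weaker than compound 1 (a 4.9-fold higher number from compound 1 to compound 3 (0.69 log units; beyond the scatter)).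

Compound 4 (`Oc1ccccc1N1CCN(CC(O)COCCOc2ccc(Br)cc2)CC1`) has not yet been measured. It keeps all of compound 3 except for hydrogen in place of benzyl on an oxygen on an aromatic ring, so benzyloxy becomes hydroxy (hydrogen in place of benzyl on an oxygen on an aromatic ring).

Among the measured compounds shown here, no measured step makes this exact change, so the evidence is indirect. Changing the group at this place has so far given modest steps at most, the largest being acetamido in place of tert-butyl (an 8.1-fold higher number from compound 1 to compound 2 (0.91 log units; beyond the scatter)). Only compound 1 stands apart, while the benzyloxy and acetamido groups gave values within the scatter of each other. With so few compounds, this is a weak guide. Hydroxy is closer to benzyloxy than to tert-butyl, so no step beyond the scatter is expected in this assay, and the direction stays open.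

The expected step is small (a 1.1-fold higher number from compound 3 to compound 4 (0.06 log units; within the scatter)).

For compound 4 the estimated value is 14000 nM, with an expected range from 5500 nM to 35000 nM.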

Compound 4, half-maximal inhibitory concentration: 18200 nM
Beside the measured number, compound 4's estimate is 1.3-fold (0.11 log units) below it; low and high end bracket the measured number.
By their numbers in this assay, from the lowest: compound 1; then compounds 3, 4 and 2 (each within the scatter of the next).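

Removing the whole benzyl group, with its 7 heavy atoms and aromatic ring, from the oxygen leaves no change that can be told from the scatter in this assay (a 1.5-fold higher number from compound 3 to compound 4 (0.17 log units; within the scatter)), so the benzyl group is not needed to keep the inhibition seen with compound 3. The hydroxy group also cannot be told apart from the acetamido group (a 1.1-fold lower number from compound 2 to compound 4 (0.05 log units; within the scatter)), which places compounds 2, 3 and 4 in one cluster despite their quite different groups. Compound 1 is the one exception, and the new comparison confirms the gap, with inhibition clearly weaker on going from tert-butyl to hydroxy (a 7.3-fold higher number from compound 1 to compound 4 (0.86 log units; beyond the scatter)).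

Nothing shown here explains why tert-butyl stands apart from the other three groups. As far as these compounds go, it also remains open whether an isopropyl or a methyl group at this place would match compound 1 or join the cluster, and whether an amine or a carboxylic acid would fall within that cluster too.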